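Swapping One Group on a Weakly Active Core

A few compounds are considered here, and "the series" means these few. Any claim that something is new, unique, unknown or untested is made for them only; others in the source may bear on it.

In a functional assay on K562-TAX cells (Homo sapiens), read by MTT assay, with a stated time of 3 days (a higher number here means a weaker inhibitor, a lower number a stronger inhibitor), compound 1 `CN(C)c1ncnc2[nH]cc(Sc3cccs3)c12` gives 22100 nM, and compound 2 `c1csc(Sc2c[nH]c3ncnc(-c4cccs4)c23)c1` gives 21700 nM, so the two sit level within the scatter. Compound 3 `COc1ncnc2[nH]cc(Sc3cccs3)c12` keeps the core of compound 1 and changes one group: methoxy in place of dimethylamino on an aromatic carbon. Among the measured compounds shown here, only one measured step touches this carbon, thiophen-2-yl in place of dimethylamino, and it is a 1.0-fold lower number from compound 1 to compound 2 (0.01 log units; within the scatter). That single step gives thin guidance, but it points to no shift beyond the scatter, and the expected step is a 1.1-fold lower number from compound 1 to compound 3 (0.04 log units; within the scatter). Compound 3 is estimated at 20000 nM, within an expected range of 9000 nM to 40000 nM.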

Compound 3, half-maximal inhibitory concentration: 44000 nM
Beside the measured number, compound 3's estimate is 2.2-fold (0.34 log units) below it, outside the stated range (above it).
By their numbers in this assay, from the lowest: compounds 2, 1 and 3 (each within the scatter of the next, the first and the last beyond it).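

In this assay, this carbon now shows its first step beyond the scatter, though a modest one: methoxy in place of thiophen-2-yl gives a 2.0-fold higher number from compound 2 to compound 3 (0.31 log units; beyond the scatter) on the shared core. Methoxy in place of dimethylamino gives a 2.0-fold higher number from compound 1 to compound 3 (0.30 log units; within the scatter) and so cannot be told apart from dimethylamino here. No evidence is available to explain the difference between these groups. On these data alone, whether a primary amine, a chlorine atom or a longer alkoxy chain on this carbon would give a clearly lower number remains open.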